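This account rests on a few compounds, and the source may have more. Where it says the series, first, only, none or still open, it means among the compounds named here.

Working notes on the series. Among the compounds with values here, compound 1 `COc1ccc(Cn2cc3cc(C(=N)Nc4ccccc4)ncc3n2)cc1` in a functional assay on PC-3 cells (Homo sapiens) for cytotoxicity, read by MTT assay, with a stated time of 72 h (on this read-out higher numbers stand for weaker inhibition and lower numbers for stronger inhibition), gives 2040 nM, and compound 2 `CN1CCN(c2ccc(NC(=N)c3cc4cn(C)nc4cn3)cc2)CC1` in this assay gives 24800 nM; the two differ in more than one place, so only the pair of values themselves is recorded here. Compound 3 `N=C(Nc1ccccc1)c1cc2cn[nH]c2cn1` in this assay gives "not determined" (no result reported): no result was reported for it, so its standing in this series cannot be fixed. Compound 4 `CN1CCN(c2ccc(NC(=N)c3cc4cn[nH]c4cn3)cc2)CC1` is the next entry and has not yet been measured in this assay. The change from compound 3 to compound 4 is 4-methylpiperazin-1-yl in place of hydrogen on an aromatic carbon. Within the data shown here, no measured step exists for this change, so the size and direction of the step in this assay remain open; with no anchor for compound 3, a step beyond the scatter in either direction cannot be ruled out. Compound 4 in this assay is expected to give 15000 nM, within a range of 4000 nM to 50000 nM.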

Compound 4, half-maximal inhibitory concentration: 45400 nM
Estimate against measurement, compound 4: 3.0-fold (0.48 log units) below; the range from low to high includes it.
By their numbers in this assay, from the lowest: compound 1; then compounds 2 and 4 (each within the scatter of the next).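

No new step can be read between compound 3 and compound 4. The compounds shown leave open what 4-methylpiperazin-1-yl in place of hydrogen does to the read-out. No measurement on hand bears on the value of compound 4.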